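Aryl swap at the amine nitrogen: working notes

The source may report more compounds than this note shows. Statements on the series, on what has been measured and on what is new or still open speak of the compounds shown alone.

Going by the values given here, compound 1 `COc1cccc(NC2=CC(=O)c3c(nc4n3[C@H]3OC[C@@H](O)[C@H]3OC4)C2=O)c1` is the only compound with a number in a functional assay on ECa-109 cells for inhibition, with ECa-109 cell line (Homo sapiens) as the target, read by sulforhodamine B assay; a higher number here means a weaker inhibitor, a lower number a stronger inhibitor; in this assay compound 1 gives 3340 nM. Compound 2 `COc1ccc(NC2=CC(=O)c3nc4n(c3C2=O)[C@H]2OC[C@@H](O)[C@H]2OC4)cc1` reaches only a limit in this assay, > 4000 nM, and (the limit of > 4000 nM in this assay, at which 1 of the 2 values shown sits). Compound 3 `O=C1C(Nc2ccc(C(F)(F)F)cc2)=CC(=O)c2c1nc1n2[C@H]2OC[C@@H](O)[C@H]2OC1` is not yet measured; from compound 1 it differs by 4-(trifluoromethyl)phenyl in place of 3-methoxyphenyl on an amine nitrogen. Among the compounds with values here, no step between measured compounds exists, so no size is known for such a change; a step no larger than the usual scatter is expected, in either direction. For compound 3 the estimate in this assay is 4000 nM, from 1500 nM to 11000 nM, which means an expected step of a 1.2-fold higher number from compound 1 to compound 3 (0.08 log units; within the scatter).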

Compound 3, half-maximal inhibitory concentration: 2250 nM
Compound 3: the middle estimate sits 1.8-fold (0.25 log units) above what was measured; the measured number falls inside the stated range.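

At this amine nitrogen, 4-(trifluoromethyl)phenyl in place of 3-methoxyphenyl gives a 1.5-fold lower number from compound 1 to compound 3 (0.17 log units; within the scatter) in this assay. This first readable step shows that the position accepts two differently substituted phenyl groups, one with a hydrogen-bond acceptor and one without, with no change beyond the scatter. Nothing measured here bears on why the two read alike.

Steps to compound 2 cannot be read: its > 4000 nM is a limit. Open, on these data alone, is whether a carboxylic acid or an amine on the phenyl ring, or a longer chain replacing that ring, would move the number.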